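Two Limits and an Unmeasured Bromohydroxyphenyl Analog

The source may report more compounds than this note shows. Statements on the series, on what has been measured and on what is new or still open speak of the compounds shown alone.

Measured compounds:
compound 1, `COc1ccc(C(=O)/C=C/c2ccc(F)cc2)c2c1C=CC(C)(C)O2` — > 10000 nM
compound 2, `COc1ccc(C(=O)/C=C/c2ccc(N(c3ccccc3)c3ccccc3)cc2)c2c1C=CC(C)(C)O2` — > 10000 nM

In a functional assay on HepG2 cells (Homo sapiens) for antiproliferative activity, read by MTT assay, with a stated time of 24 h (a higher number here means a weaker inhibitor, a lower number a stronger inhibitor), compound 1 gives > 10000 nM, which is a limit of the assay and not a number. In this assay compound 2 also gives > 10000 nM, again a limit rather than a number. Compound 1 therefore stands nowhere in particular on the numbers shown: both values sit at the limit of > 10000 nM in this assay, at which 2 of the 2 values shown sit, and no step between measured compounds can be read off.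

Compound 3, `COc1ccc(C(=O)/C=C/c2ccc(O)c(Br)c2)c2c1C=CC(C)(C)O2`, shares the core of compound 1 and differs from it in one place: 3-bromo-4-hydroxyphenyl in place of 4-fluorophenyl on a double-bonded chain carbon bound to a double-bonded chain carbon. For the measured compounds named here, with no measured step to lean on, the expectation for compound 3 rests only on the fact that the two measured compounds sit at a limit and that the change introduces a hydrogen-bond donor and acceptor. The step from compound 1 to compound 3 is expected to be a modest gain, an at least 1.4-fold lower number from compound 1 to compound 3 (0.15 log units; that floor lies within the scatter), though a value that again stops at the limit cannot be ruled out. For compound 3 the estimated half-maximal inhibitory concentration in this assay is 7000 nM, in a range from 2000 nM to 30000 nM.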

Compound 3, half-maximal inhibitory concentration: > 10000 nM
Compound 3: a limit, no number (the forecaster's own chance of this, stated with the estimate: 50%); middle value at least 1.4-fold (0.15 log units) away from the limit.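

For the compounds shown here, compound 3, like compound 1, gives only a limit and not a number in this assay, so no step between these two compounds can be read: the limit of > 10000 nM in this assay, at which 3 of the 3 values shown sit.

Going by these compounds, how far each compound lies past that limit stays open, as does whether 3-bromo-4-hydroxyphenyl in place of 4-fluorophenyl changes the antiproliferative activity at all.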